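The source may hold more compounds than are shown below. What is called first, only, known or untested is meant among the compounds shown, and "the series" means these compounds.

Measured so far:
compound 1 `Nc1ccccc1NC(=O)/C=C/c1ccc(CSc2ccc(F)cc2)cc1` — 3670 nM
compound 2 `Nc1ccccc1NC(=O)c1ccc(CSc2cccc(F)c2)cc1` — 3900 nM
compound 3 `COC(=O)c1ccccc1SCc1ccc(C(=O)Nc2ccccc2N)cc1` — 3610 nM

In a functional assay on A-375 cells (Homo sapiens) for antiproliferative activity, read by CCK-8 assay, with a stated time of 72 h (a higher number here means a weaker inhibitor, a lower number a stronger inhibitor), compound 2 gives the highest of the three numbers, yet compound 1 and compound 3 both sit within the usual scatter of it, so no order among the three is claimed and none is called weaker or stronger than another. Going by the values given here, no step between two measured compounds differing in one place is available, so nothing here anchors the size of a single change.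

Compound 4 `Nc1ccccc1NC(=O)c1ccc(CSCCc2ccccc2)cc1` has not yet been measured. Relative to compound 2 the change is phenethyl in place of 3-fluorophenyl on a sulfur. The three measured values give no guide to what this exchange on the sulfur does, and nothing in them points in either direction. The expectation is therefore a step of no size beyond the scatter from compound 2 to compound 4 in this assay, with a wide range to reflect the lack of any anchoring step.

For compound 4 the estimate in this assay is 3900 nM, with a range from 1500 nM to 10000 nM. This estimate corresponds to an expected step of no change at the digits printed from compound 2 to compound 4 (within the scatter).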

Compound 4, half-maximal inhibitory concentration: 2860 nM
Estimate against measurement, compound 4: 1.4-fold (0.13 log units) above; low and high end bracket the measured number.
By their numbers in this assay, from the lowest: compounds 4, 3, 1 and 2 (each within the scatter of the next).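

In this assay the series now has its first step in one place, a 1.4-fold lower number from compound 2 to compound 4 (0.13 log units; within the scatter) for phenethyl in place of 3-fluorophenyl on a sulfur. This position on the sulfur therefore accepts either group without a change beyond the scatter, although both carry one six-membered aromatic ring of carbon only, so the step tests a narrow exchange. No available data bear on why the two compounds lie this close.

Still open, on these data alone, is whether that tolerance holds when the aromatic ring is absent, as with a plain butyl chain on the sulfur, or when the chain ending in the ring is longer than phenethyl. Also open, as far as these compounds go, is how a primary amine or a carboxylic acid at the end of such a chain would read in this assay.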